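This account rests on a few compounds, and the source may have more. Where it says the series, first, only, none or still open, it means among the compounds named here.

Measured so far in an ADME assay on microsomes from liver (Homo sapiens) for metabolic stability, read by LC-MS, using NADPH, with a stated time of 10 min, tested at 0.5 uM; a higher number here means that more of the compound is left, a lower number that less of the compound is left:
compound 1 `Cc1cc(-c2ccnc(C(F)F)c2)ncc1OC[C@@](C)(N)CC(C)C`; compound 1 gives 83%
compound 2 `COC(=O)Nc1cc(-c2cc(Cl)c(OC[C@@](C)(N)CC(C)C)cn2)ccn1`; compound 2 gives 96%
compound 3 `CC(C)C[C@](C)(N)COc1cnc(-c2ccnc(Cl)c2)cc1Cl`; compound 3 gives 86%

Compound 2 stands highest of the three numbers; the step of a number 10 percentage points lower from compound 2 to compound 3 (within the scatter) is within the scatter, and only the gap to compound 1 lies beyond it. Compound 4 `COC(=O)Nc1cc(-c2cc(C)c(OC[C@@](C)(N)CC(C)C)cn2)ccn1` has not yet been measured. The change: methyl in place of chloro on an aromatic carbon. Among the compounds with values here, no measured step exchanges chloro for methyl at this carbon. Compound 1 carries methyl and compound 3 carries chloro, but each differs from compound 2 elsewhere, so their values show only that both variants stay in a high range. The expected step of a number 6 percentage points lower from compound 2 to compound 4 (within the scatter) is therefore small, not beyond the scatter. Compound 4 is estimated at 90%, with a range of 78% to 99%.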

Compound 4, percent of the compound remaining: 100%
The estimate for compound 4 lay 10 percentage points below the measured number, outside the stated range (above it).
By their numbers in this assay, from the lowest: compounds 1, 3, 2 and 4 (each within the scatter of the next, the first and the last beyond it).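

In this assay, chloro and methyl on the carbon opposite the ring nitrogen can now be compared directly: a number 4 percentage points higher from compound 2 to compound 4 (within the scatter), so this exchange does not separate the two compounds. With methyl in place in both compounds, (methoxycarbonyl)amino in place of difluoromethyl on an aromatic carbon gives a number 17 percentage points higher from compound 1 to compound 4 (beyond the scatter), a change at a different place from the chloro-to-methyl exchange. No available measurement explains either step.

From the compounds shown here alone, whether an amine or a methoxy group at this carbon would keep the number as high remains open. Also open, going by these compounds, is whether methyl and chloro stay level without the (methoxycarbonyl)amino group.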